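Moving a Ring Substituent on a Changed Core

A few compounds are considered here, and "the series" means these few. Any claim that something is new, unique, unknown or untested is made for them only; others in the source may bear on it.

Three compounds share a related scaffold and were tested in a functional assay on KB cells (Homo sapiens) for cytotoxicity, read by sulforhodamine B assay; on this read-out higher numbers stand for an effect only at larger amounts of compound and lower numbers for an effect already at smaller amounts. Compound 2 `CCc1ccc(-c2cc(=O)c3c(o2)C(C)(C)C(=O)C(C)=C3O)cc1` gives 20 ug/mL in this assay. Compound 1 `CC1=C(O)c2c(oc(-c3ccccc3C)cc2=O)C(C)(C)C1=O` differs from compound 2 by 2-methylphenyl in place of 4-ethylphenyl on an aromatic carbon, and in this assay compound 1 gives 37.3 ug/mL. The step of a 1.9-fold higher number from compound 2 to compound 1 (0.27 log units; within the scatter) is therefore small and does not stand out from repeated measurement. Compound 3 `CCC1=C(O)c2c(oc(-c3ccc(CC)cc3)cc2=O)C(CC)(CC)C1=O` carries a different core; how its core differs from that of compound 2 is not broken down here. In this assay compound 3 gives 8 ug/mL, the lowest of the three numbers, and its values stand apart from those of compound 2 and compound 1 by more than the usual scatter.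

Compound 4 `CCC1=C(O)c2c(oc(-c3ccccc3C)cc2=O)C(CC)(CC)C1=O` has not been measured yet. It differs from compound 3 by 2-methylphenyl in place of 4-ethylphenyl on an aromatic carbon, which is the same change, at the same place, as that from compound 2 to compound 1. The expectation for compound 4 rests on the measured pair: because a 1.9-fold higher number from compound 2 to compound 1 (0.27 log units; within the scatter) was a small step, a step of similar size, a 1.9-fold higher number from compound 3 to compound 4 (0.27 log units; within the scatter), is expected from compound 3 to compound 4. Whether the changed core of compound 3 alters the size of this step cannot be judged from the data at hand, so the range is kept wide. Compound 4 is accordingly estimated at 15 ug/mL in this assay, with a plausible span from 7 ug/mL to 32 ug/mL.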

Compound 4, concentration for half-maximal effect: 18 ug/mL
Compound 4: middle estimate off by 1.2-fold (0.08 log units), on the low side, within the range that was stated.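

In this assay, putting 2-methylphenyl in place of 4-ethylphenyl on the core of compound 3 gives a 2.3-fold higher number from compound 3 to compound 4 (0.35 log units; beyond the scatter), a modest step. Set beside the same exchange on the core of compound 2, the step keeps its direction and does not differ measurably in size: the same change on two cores in this assay, a 1.9-fold higher number (0.27 log units; within the scatter) from compound 2 to compound 1 and a 2.3-fold higher number (0.35 log units; beyond the scatter) from compound 3 to compound 4, 1.2-fold (0.08 log units) apart, within the scatter of two such steps. This shows that, on these two cores, the exchange moves the number the same way and by a similar amount, with the core of compound 3 keeping its lower numbers; it does not show a general rule for the series, as it rests on one pair per core, the earlier step alone lies within the scatter, and nothing here explains the step.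

The compounds shown leave open how the number would move with an amine or a carboxylic acid on the phenyl ring, or with a longer chain such as butyl in place of the ethyl groups on the core of compound 3. Going by these compounds alone, also open is whether the step follows from the change of chain or from its changed place on the phenyl ring; the single exchange alters both at once.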